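This account rests on a few compounds, and the source may have more. Where it says the series, first, only, none or still open, it means among the compounds named here.

Of the compounds shown here, three of a shared core have been measured in an ADME assay on NIH3T3 cells (Mus musculus) for cytotoxicity, read by MTT assay, with a stated time of 48 h; a higher number here means a weaker inhibitor, a lower number a stronger inhibitor. Compound 1 `CC(=O)OC1=C(c2cccc3cccnc23)Oc2cc3ccccc3cc2-n2cccc21` gives 34 nM. Compound 2 `CCN(CC)CCCC(C)NC(=O)OC1=C(c2cccc3cccnc23)Oc2cc3ccccc3cc2-n2cccc21`, which carries a carbamate in place of the acetate, gives 2300 nM, a change recorded as a 68-fold higher number from compound 1 to compound 2 (1.83 log units; beyond the scatter). Compound 3 `CC(=O)OC1=C(c2cc(C)nc3ccccc23)Oc2cc3ccccc3cc2-n2cccc21` gives 126 nM, a change from compound 1 recorded as a 3.7-fold higher number from compound 1 to compound 3 (0.57 log units; beyond the scatter). Among the three, compound 3 thus holds the second highest number: its nearest neighbour is compound 1, and compound 2 lies furthest from it.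

Compound 4 `CCN(CC)C(=O)OC1=C(c2cc(C)nc3ccccc23)Oc2cc3ccccc3cc2-n2cccc21` is not yet measured. It differs from compound 3 in one place: diethylamino in place of methyl on a carbonyl carbon. Within the data shown here, the step that bears on this is the one from compound 1 to compound 2, where the acetate also became a carbamate and the number rose by a 68-fold higher number from compound 1 to compound 2 (1.83 log units; beyond the scatter). The group entering here is smaller than the one that entered there, so a rise is expected, but a smaller one. Compound 4 is therefore expected to give about 600 nM, within 200 nM to 2500 nM. That expectation corresponds to an estimated step of a 4.8-fold higher number from compound 3 to compound 4 (0.68 log units; beyond the scatter).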

Compound 4, half-maximal inhibitory concentration: 4950 nM
Estimate against measurement, compound 4: 8.3-fold (0.92 log units) below, and the stated range ends below it.
By their numbers in this assay, from the lowest: compound 1; then compound 3; then compound 2; then compound 4.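

In this assay, the step of a 39-fold higher number from compound 3 to compound 4 (1.59 log units; beyond the scatter) shows that a carbamate in place of the acetate also brings a large rise when 2-methylquinolin-4-yl is present, so the effect is not confined to the quinolin-8-yl pair, whose step was a 68-fold higher number from compound 1 to compound 2 (1.83 log units; beyond the scatter). It also shows that a large rise does not need the longer (4-(diethylamino)-1-methylbutyl)amino group, since diethylamino on the carbonyl carbon is enough. Nothing available here accounts for the size of either rise.

The two steps differ in both the entering group and the quinolinyl group, so the compounds shown leave open which of these sets the size of the rise. Diethylamino paired with quinolin-8-yl, or a smaller amine such as dimethylamino on the carbonyl carbon, would bear on that question.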